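Amine-to-amide change at the ring carbon of compound 2

A few compounds are considered here, and "the series" means these few. Any claim that something is new, unique, unknown or untested is made for them only; others in the source may bear on it.

Measured so far in a functional assay on BMMC cells (Mus musculus, strain C57BL/6) for inhibition, with stated times of 5 days and 48 h; on this read-out lower numbers stand for stronger inhibition and higher numbers for weaker inhibition:
- compound 1 `C=C1CC[C@@H]2[C@](C)(CNCc3ccc(OC)c(OC)c3)[C@H](O)CC[C@@]2(C)[C@@H]1/C=C/C1=CCOC1=O`: 3740 nM
- compound 2 `C=C1CC[C@@H]2[C@](C)(CNCc3ccc(Br)cc3)[C@H](O)CC[C@@]2(C)[C@@H]1/C=C/C1=CCOC1=O`: 430 nM
- compound 3 `C=C1CC[C@@H]2[C@](C)(CNCc3ccc([N+](=O)[O-])cc3)[C@H](O)CC[C@@]2(C)[C@@H]1/C=C/C1=CCOC1=O`: 1340 nM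

Compound 2 holds the lowest number of the three; compound 3 is nearest, and compound 1 furthest. The steps among the measured compounds all concern the aryl substituent on the saturated chain carbon bound to the amine nitrogen: an 8.7-fold lower number from compound 1 to compound 2 (0.94 log units; beyond the scatter), a 2.8-fold lower number from compound 1 to compound 3 (0.45 log units; beyond the scatter) and a 3.1-fold higher number from compound 2 to compound 3 (0.49 log units; beyond the scatter). Each is beyond the scatter and each favours bromo.

Compound 4 `C=C1CC[C@H]2[C@@](C)(CC[C@@H](O)[C@@]2(C)C(=O)NCc2ccccc2)[C@@H]1/C=C/C1=CCOC1=O` differs from compound 2 by benzylcarbamoyl in place of ((4-bromobenzyl)amino)methyl on a saturated ring carbon. Among the compounds with values here, no measured step covers this change: the amine becomes an amide, and the bromo is lost without a replacement. Within the data shown here, the only guide is that the two measured steps away from bromo both raised the number. Among the measured compounds shown here, an increase of modest size is therefore expected for compound 4 in this assay, a 4.7-fold higher number from compound 2 to compound 4 (0.67 log units; beyond the scatter), with wide uncertainty because the carbonyl itself has no precedent here. The estimate for compound 4 is 2000 nM, in the range 500 nM to 8000 nM.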

Compound 4, half-maximal inhibitory concentration: 19400 nM
The estimate for compound 4 lay 9.7-fold (0.99 log units) below the measured number; the measured number lies above the stated range.
By their numbers in this assay, from the lowest: compound 2; then compound 3; then compound 1; then compound 4.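

In this assay, the step of a 45-fold higher number from compound 2 to compound 4 (1.65 log units; beyond the scatter) is wider than an 8.7-fold lower number from compound 1 to compound 2 (0.94 log units; beyond the scatter), the widest step among the aryl substituents, so the change at this saturated ring carbon moves the number further than any aryl change shown. The group that leaves and the group that enters both count 10 heavy atoms and carry the same hydrogen-bond donor and acceptor counts, so these counts do not separate a group that gives the low number from one that gives the high number; what differs is the carbonyl in place of the methylene link, together with the loss of bromo. No data shown bear on the reason for this rise.

The size of the step remains undivided: a 4-bromobenzylcarbamoyl group or an unsubstituted benzylaminomethyl group at this ring carbon would show how much of it goes with the carbonyl and how much with the bromo. Also open, on these data alone, is how the number responds at this ring carbon to a carboxylic acid, or to a longer chain between the nitrogen and the aromatic ring.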